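The compounds below may be only part of what the source reports. "The series", "measured", "known", "first", "only" and "open" are said of these compounds alone.

Measured in a functional assay on C6 cells (Rattus norvegicus) for inhibition, read by sulforhodamine B assay, with a stated time of 72 h; a higher number here means that more compound is needed for the effect, a lower number that less compound is needed:
Compound 1 `O=C(/C=C/c1ccc([N+](=O)[O-])o1)c1ccc(Br)cc1`: 2700 nM
Compound 2 `CSc1ccc(C(=O)/C=C/c2ccc([N+](=O)[O-])o2)cc1`: 1600 nM
Compound 3 `O=C(/C=C/c1ccc([N+](=O)[O-])o1)c1ccc(-n2ccnc2)cc1`: 3500 nM

All three compounds share one core and differ in a single group on an aromatic carbon. Compound 3 lies close to compound 1, the comparison showing a 1.3-fold higher number from compound 1 to compound 3 (0.11 log units; within the scatter). Its distance from compound 2 is modest but real, at a 2.2-fold higher number from compound 2 to compound 3 (0.34 log units; beyond the scatter).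

The next compound, compound 4 `O=C(/C=C/c1ccc([N+](=O)[O-])o1)c1ccc(N2CCCC2)cc1`, keeps the same core and changes that group once more: pyrrolidin-1-yl in place of 1H-imidazol-1-yl on an aromatic carbon. A five-membered non-aromatic ring thus takes the place of a five-membered aromatic ring.

Among the measured compounds shown here, no measured step involves pyrrolidin-1-yl, so the evidence is indirect. Three exchanges at this place bear on it. Two stayed small, a 1.7-fold lower number from compound 1 to compound 2 (0.23 log units; within the scatter) and a 1.3-fold higher number from compound 1 to compound 3 (0.11 log units; within the scatter), and the largest, a 2.2-fold higher number from compound 2 to compound 3 (0.34 log units; beyond the scatter), only just cleared the usual scatter. Nothing here points to a large change in this assay, so no step beyond the scatter is expected. A slight lean towards a lower number is allowed, since compound 3 sits at the upper end of the small set, but the data do not establish that direction. The expected step is a 1.4-fold lower number from compound 3 to compound 4 (0.15 log units; within the scatter). For compound 4 the estimate is 2500 nM, with an expected range of 1100 nM to 5500 nM.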

Compound 4, half-maximal effective concentration: 16400 nM
Estimate against measurement, compound 4: 6.6-fold (0.82 log units) below, outside the stated range (above it).
By their numbers in this assay, from the lowest: compounds 2, 1 and 3 (each within the scatter of the next, the first and the last beyond it); then compound 4.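

In this assay this position turns out to be able to carry a clear loss, which the bromo, methylsulfanyl and 1H-imidazol-1-yl groups had not shown: pyrrolidin-1-yl brings a 4.7-fold higher number from compound 3 to compound 4 (0.67 log units; beyond the scatter) and also a 6.1-fold higher number from compound 1 to compound 4 (0.78 log units; beyond the scatter) and a 10-fold higher number from compound 2 to compound 4 (1.01 log units; beyond the scatter) with the last of these the only large step in the set. Compound 4 therefore stands apart from compounds 1, 2 and 3, and the exchange of a five-membered aromatic ring for a five-membered non-aromatic ring, with the heavy-atom count unchanged, is not a neutral one at this place. Nothing measured here accounts for the step, and no data on any property of these groups stand behind it.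

As far as these compounds go, whether the loss follows the non-aromatic ring itself or the nitrogen attached to the aromatic carbon stays open, as does what a dimethylamino group, a piperidine ring or a morpholine ring would do at this place. From the compounds shown here alone, whether compound 4 stands apart in the same way outside this assay also remains open.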